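The source may report more compounds than this note shows. Statements on the series, on what has been measured and on what is new or still open speak of the compounds shown alone.

In a functional assay on HCT-116 cells (Homo sapiens) for inhibition, read by fluorescence, with a stated time of 48 h (on this read-out lower numbers stand for stronger inhibition of growth and higher numbers for weaker inhibition of growth), compound 1 (`N[C@H](C(=O)OCCCOC1(c2ccc(Cl)cc2)c2ccccc2C(=O)N1Cc1ccc(Cl)cc1)c1ccccc1`) reads 45000 nM while compound 2 (`CC(=O)OCCCOC1(c2ccc(Cl)cc2)c2ccccc2C(=O)N1Cc1ccc(Cl)cc1`) reads 68000 nM and compound 3 (`CC(=O)OCCCOC1(c2ccc(Cl)cc2)c2ccccc2C(=O)N1Cc1ccccc1`) reads 80000 nM on the same test. Compound 2 sits mid-way among these numbers, with both its gaps inside the scatter. Compound 4 (`CC(=O)OCC(C)(C)COC1(c2ccc(Cl)cc2)c2ccccc2C(=O)N1Cc1ccc(Cl)cc1`) carries 1-(acetoxymethyl)-1-methylethyl in place of 2-acetoxyethyl on a saturated chain carbon bound to an oxygen on a saturated carbon. Among the measured compounds shown here, no measured step touches this chain. The nearest guides lie elsewhere in the molecule: a 1.5-fold higher number from compound 1 to compound 2 (0.18 log units; within the scatter) and a 1.2-fold higher number from compound 2 to compound 3 (0.07 log units; within the scatter) are both small and neither goes beyond the scatter. Starting from compound 2 at 68000 nM with steps that small, no shift beyond the scatter is expected in this assay here. The estimated step is a 1.1-fold lower number from compound 2 to compound 4 (0.05 log units; within the scatter) in this test. For compound 4 the expected value is 60000 nM with a range of 28000 nM to 110000 nM.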

Compound 4, concentration for 50% growth inhibition: 70000 nM
Beside the measured number, compound 4's estimate is 1.2-fold (0.07 log units) below it; the measured number falls inside the stated range.
By their numbers in this assay, from the lowest: compounds 1, 2, 4 and 3 (each within the scatter of the next).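

Exchanging 2-acetoxyethyl for 1-(acetoxymethyl)-1-methylethyl is the first change shown on this chain, and in this assay it stays within the scatter (a 1.0-fold higher number from compound 2 to compound 4 (0.01 log units; within the scatter)). Compound 2 and compound 4 therefore read alike, so in this pair the assay does not distinguish the larger, branched chain from the smaller, unbranched one. No supporting measurement offers an explanation for this result. Still open, as far as these compounds go, is whether a longer chain, or an amine or a carboxylic acid in place of the acetoxy group, would also read alike.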